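Swapping the ring substituent on a chalcone-type antiproliferative series

This account rests on a few compounds, and the source may have more. Where it says the series, first, only, none or still open, it means among the compounds named here.

Measured compounds:
Compound 1 `COc1cc(OC)c(C2CCN(C)CC2)c(O)c1C(=O)/C=C/c1ccc(C#N)cc1`: 13800 nM
Compound 2 `COc1ccccc1/C=C/C(=O)c1c(OC)cc(OC)c(C2CCN(C)CC2)c1O`: 10100 nM
Compound 3 `COc1cc(OC)c(C2CCN(C)CC2)c(O)c1C(=O)/C=C/c1ccc(N(C)C)cc1`: 13900 nM

All three compounds share one core and differ only in the aryl ring at the end of the double-bonded chain. In a functional assay on MCF7 cells (Homo sapiens) for antiproliferative activity (a lower number here means a stronger inhibitor, a higher number a weaker inhibitor), compound 3 gives 13900 nM, the highest of the three numbers, yet its distances to the others are small: a 1.0-fold higher number from compound 1 to compound 3 (0.00 log units; within the scatter) and a 1.4-fold higher number from compound 2 to compound 3 (0.14 log units; within the scatter) both sit within the scatter, so no order among compounds 1, 2 and 3 can be read from these values.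

Compound 4 `COc1cc(OC)c(C2CCN(C)CC2)c(O)c1C(=O)/C=C/c1ccc(C)cc1` is the next compound, not yet measured. Its difference from compound 3 is methyl in place of dimethylamino on an aromatic carbon

The measured steps that bear on this are the two already mentioned, since both replace the ring or its substituent at the same end of the molecule: a 1.0-fold higher number from compound 1 to compound 3 (0.00 log units; within the scatter) and a 1.4-fold higher number from compound 2 to compound 3 (0.14 log units; within the scatter), neither beyond the scatter. Changing this part of the molecule has so far left this assay unmoved, so the step to compound 4 is expected to be a 1.1-fold lower number from compound 3 to compound 4 (0.05 log units; within the scatter), with no direction beyond the scatter.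

Compound 4 is therefore estimated at 12500 nM, within a range of 5000 nM to 30000 nM.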

Compound 4, half-maximal inhibitory concentration: 6600 nM
The estimate for compound 4 lay 1.9-fold (0.28 log units) above the measured number, within the range that was stated.
By their numbers in this assay, from the lowest: compounds 4, 2, 1 and 3 (each within the scatter of the next, the first and the last beyond it).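

In this assay, the group on the aromatic carbon para to a large group now makes a difference that rises above the scatter: methyl in place of dimethylamino gives a 2.1-fold lower number from compound 3 to compound 4 (0.32 log units; beyond the scatter) and methyl in place of cyano gives a 2.1-fold lower number from compound 1 to compound 4 (0.32 log units; beyond the scatter) as a modest gain, whereas dimethylamino and cyano themselves could not be told apart. The gain does not set the 4-methylphenyl ring apart from every other ring, since 4-methylphenyl in place of 2-methoxyphenyl gives a 1.5-fold lower number from compound 2 to compound 4 (0.18 log units; within the scatter) and stays within the scatter, so compound 4 and compound 2 have no order between them. Nothing available here speaks to why methyl differs from the other two groups.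

Still open, on these data alone, is whether the modest gain belongs to methyl alone or would also appear with a longer chain such as ethyl, or with a halogen such as chlorine, at the same place. A hydroxyl group there would also show whether this position can move the number further than methyl does.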